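From a Propylpiperazine Chain to a Triazole Diol

The source may report more compounds than this note shows. Statements on the series, on what has been measured and on what is new or still open speak of the compounds shown alone.

In a functional assay on A-375 cells (Homo sapiens) for cytotoxicity, read by MTT assay, with a stated time of 72 h (on this read-out higher numbers stand for weaker inhibition and lower numbers for stronger inhibition), compound 1 (`CN(C)CCCCCn1c2c(c3ccccc31)C(=O)c1c[n+]([O-])c3ccccc3c1C2=O`) gives 560 nM, compound 2 (`CC1(C)OC[C@H](Cn2cc(Cn3c4c(c5ccccc53)C(=O)c3c[n+]([O-])c5ccccc5c3C4=O)nn2)O1`) gives 180 nM and compound 3 (`CCCN1CCN(CCCCn2c3c(c4ccccc42)C(=O)c2c[n+]([O-])c4ccccc4c2C3=O)CC1`) gives 870 nM. Compound 3 therefore matches compound 1 within the scatter, while its number lies clearly above that of compound 2. Compound 4 (`O=C1c2c[n+]([O-])c3ccccc3c2C(=O)c2c1c1ccccc1n2Cc1cn(C[C@@H](O)CO)nn1`) carries 1-(2,3-dihydroxypropyl)-1H-1,2,3-triazol-4-yl in place of 3-(4-propylpiperazin-1-yl)propyl on a saturated chain carbon bound to an aromatic nitrogen. Within the data shown here, the only measured single-place step, a 1.6-fold higher number from compound 1 to compound 3 (0.19 log units; within the scatter), does not involve a triazole, so it offers little guidance. Compound 2 also holds a triazole ring and gives 180 nM, which points to a lower number in this assay. The expected step is a 3.1-fold lower number from compound 3 to compound 4 (0.49 log units; beyond the scatter). Compound 4 is estimated at 280 nM, within a range of 90 nM to 800 nM.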

Compound 4, half-maximal inhibitory concentration: 140 nM
The estimate for compound 4 lay 2.0-fold (0.30 log units) above the measured number; low and high end bracket the measured number.
By their numbers in this assay, from the lowest: compounds 4 and 2 (each within the scatter of the next); then compounds 1 and 3 (each within the scatter of the next).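

In this assay, 1-(2,3-dihydroxypropyl)-1H-1,2,3-triazol-4-yl on the saturated chain carbon bound to an aromatic nitrogen gives a 6.2-fold lower number from compound 3 to compound 4 (0.79 log units; beyond the scatter) and a 4.0-fold lower number from compound 1 to compound 4 (0.60 log units; beyond the scatter), so it outperforms both amine chains beyond the scatter. Its free diol and the 2,2-dimethyl-1,3-dioxolan-4-yl form cannot be told apart, with a 1.3-fold lower number from compound 2 to compound 4 (0.11 log units; within the scatter). Both triazole compounds thus sit clear of the amine chains, whether the diol is free or capped.

As far as these compounds go, whether a carboxylic acid or a longer chain on the triazole would keep this number remains open. Nothing measured here explains why the triazole compounds give lower numbers.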